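The compounds below may be only part of what the source reports. "The series", "measured", "known", "first", "only" and "open" are said of these compounds alone.

Compound 1 `CCCN1CC(=O)N(Cc2ccc(C(=O)NO)cc2)C1=O` gives 53.4 nM in an assay on isolated protein for inhibition of protein deacetylase HDAC6 (Homo sapiens), read by fluorescence, with stated times of 10 min and 2 h; on this read-out lower numbers stand for stronger inhibition and higher numbers for weaker inhibition. Compound 2 `O=C(NO)c1ccc(CN2C(=O)CN(Cc3ccccc3)C2=O)cc1` gives 12.5 nM. Compound 3 `Cc1ccc(CN2CC(=O)N(Cc3ccc(C(=O)NO)cc3)C2=O)cc1` gives 17.6 nM.

Compound 2 has the lowest number of the three, but its gap to compound 3, a 1.4-fold higher number from compound 2 to compound 3 (0.15 log units; within the scatter), lies within the scatter, so the two cannot be ordered; only compound 1 stands apart, with a 4.3-fold lower number from compound 1 to compound 2 (0.63 log units; beyond the scatter) beyond the scatter. Compound 4 `COc1ccc(CN2CC(=O)N(Cc3ccc(C(=O)NO)cc3)C2=O)cc1` is built from compound 2 by methoxy in place of hydrogen on an aromatic carbon. The step that bears on this change is the methyl added on the same aromatic carbon, a 1.4-fold higher number from compound 2 to compound 3 (0.15 log units; within the scatter), which stayed within the scatter. Another single substituent on that carbon is therefore expected to leave the number roughly unchanged, a step of a 1.2-fold higher number from compound 2 to compound 4 (0.08 log units; within the scatter) expected within the scatter. Compound 4 is estimated at 15 nM, with a range from 7 nM to 35 nM.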

Compound 4, half-maximal inhibitory concentration: 28.2 nM
Compound 4: middle estimate off by 1.9-fold (0.27 log units), on the low side, within the range that was stated.
By their numbers in this assay, from the lowest: compounds 2, 3, 4 and 1 (each within the scatter of the next, the first and the last beyond it).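

Methoxy on this aromatic carbon gives a 2.3-fold higher number from compound 2 to compound 4 (0.35 log units; beyond the scatter) and is the first group there to move the number clearly, so the position is not indifferent to what it carries. Methoxy and methyl cannot be told apart, with a 1.6-fold higher number from compound 3 to compound 4 (0.20 log units; within the scatter) separating them. Unlike phenyl and 4-methylphenyl, 4-methoxyphenyl in place of ethyl gives only a 1.9-fold lower number from compound 1 to compound 4 (0.28 log units; within the scatter) and does not stand clear of the scatter.

Nothing shown here accounts for the step from hydrogen to methoxy. As far as these compounds go, how a chlorine atom, an amine or a carboxylic acid on this same carbon would read remains open.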